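A few compounds are considered here, and "the series" means these few. Any claim that something is new, unique, unknown or untested is made for them only; others in the source may bear on it.

Two compounds have been measured in a functional assay on MCF7 cells (Homo sapiens) for cytotoxicity, read by MTT assay, with a stated time of 24 h, tested at 1.6 ug/mL; a higher number here means a stronger effect of the compound at the concentration tested, a lower number a weaker effect:

Compound 1, `Cn1c(-c2ccc(NC(=O)CSc3nc4ccccc4s3)cc2)nc(-c2ccccc2)c1-c1ccccc1`: 2.1%
Compound 2, `Cn1c(-c2ccc(NC(=O)CSC3=NCCS3)cc2)nc(-c2ccccc2)c1-c1ccccc1`: 16.2%

Among the measured compounds shown here, compound 2 stands highest of the two numbers; the only other measured compound is compound 1, and the single known step is a number 14.1 percentage points higher from compound 1 to compound 2 (beyond the scatter). That step exchanges groups on a sulfur and keeps the sulfur in place.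

Compound 3, `CN1CCN(CC(=O)Nc2ccc(-c3nc(-c4ccccc4)c(-c4ccccc4)n3C)cc2)CC1`, has not been measured. It differs from compound 2 by a group of 7 heavy atoms (5 carbon, 2 nitrogen; one six-membered non-aromatic ring with 2 hetero atoms) in place of a group of 6 heavy atoms (3 carbon, 1 nitrogen, 2 sulfur; one five-membered non-aromatic ring with 2 hetero atoms), on a saturated chain carbon bound to a carbonyl carbon. Here the sulfur-bearing group is removed altogether and a ring of a different kind takes its place, so the measured step from compound 1 to compound 2 does not speak to this exchange directly. For the measured compounds named here, both measured compounds give low numbers in this assay, and no measured pair shows what a change at this chain carbon does. The expectation is therefore a step of a number 4.2 percentage points lower from compound 2 to compound 3 (within the scatter), that is none beyond the scatter, with wide uncertainty. For compound 3 the estimate in this assay is 12%, expected to fall between 0% and 35%.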

Compound 3, a percentage reported as activity, at one concentration (the size of the read-out at that concentration, not a potency): 2.9%
Compound 3: the middle estimate sits 9.1 percentage points above what was measured; the measured number falls inside the stated range.
By their numbers in this assay, from the lowest: compounds 1 and 3 (each within the scatter of the next); then compound 2.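

In this assay, among the compounds shown here, putting 4-methylpiperazin-1-yl on the saturated chain carbon bound to a carbonyl carbon gives a number 13.3 percentage points lower from compound 2 to compound 3 (beyond the scatter), the first sign that a group with no sulfur at this place can give a number clearly different from that of compound 2. The other comparison gives a number 0.8 percentage points higher from compound 1 to compound 3 (within the scatter), so 4-methylpiperazin-1-yl and (1,3-benzothiazol-2-yl)sulfanyl, two very different groups, cannot be told apart here, and among these three compounds only compound 2 stands clear of the others. Nothing reported with these numbers explains why the group in compound 2 stands apart.

From the compounds shown here alone, it remains open whether a morpholin-4-yl ring or an open-chain dimethylamino group on the same chain carbon would stay level with compound 3 or come closer to compound 2, and whether a thiazol-2-ylsulfanyl group would do the same. Since every number comes from a single tested concentration, the compounds show only which gives a stronger or weaker effect at that concentration and leave open how the three would compare at other concentrations.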